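Sulfamoyl carbamates and ureas: acyltransferase inhibition notes

This account rests on a few compounds, and the source may have more. Where it says the series, first, only, none or still open, it means among the compounds named here.

Measured so far:
compound 1 `C=CCN(CC)S(=O)(=O)NC(=O)Nc1c(C(C)C)cccc1C(C)C` with 2100 nM
compound 2 `Cc1cc(C(C)(C)C)c(OC(=O)NS(=O)(=O)N(C(C)C)C(C)C)c(C(C)(C)C)c1` with 3200 nM

Both numbers come from an assay on liver for inhibition of sterol O-acyltransferase 1 (Rattus norvegicus), using microsomes; a lower number here means a stronger inhibitor, a higher number a weaker inhibitor. Compound 1 and compound 2 share the sulfamoyl linkage on a hindered aromatic core; compound 2 carries a carbamate oxygen where compound 1 carries a urea nitrogen. In this assay compound 2 gives 3200 nM and compound 1 gives 2100 nM; the two values lie within the usual scatter of each other, so no ranking between them is supported by the data.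

Compound 3 `CCCCN(CCCC)S(=O)(=O)NC(=O)Oc1c(C(C)(C)C)cc(C)cc1C(C)(C)C` is not yet measured. It differs from compound 2 in one place: dibutylamino in place of diisopropylamino on a sulfonyl sulfur. Within the data shown here, no measured pair shows this kind of exchange, so there is nothing to project from. The step from compound 2 to compound 3 is expected to be a 1.1-fold lower number from compound 2 to compound 3 (0.03 log units; within the scatter), not beyond the scatter in either direction. For compound 3 the expected value in this assay is 3000 nM, with a range from 1000 nM to 9000 nM.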

Compound 3, half-maximal inhibitory concentration: 3200 nM
Compound 3: the middle estimate sits 1.1-fold (0.03 log units) below what was measured; low and high end bracket the measured number.
By their numbers in this assay, from the lowest: compounds 1, 2 and 3 (each within the scatter of the next).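

Dibutylamino in place of diisopropylamino on a sulfonyl sulfur gives no change at the digits printed from compound 2 to compound 3 (within the scatter) in this assay. Among these compounds, this is the first exchange that can be read at this position, and with the rest of compound 2 held fixed, the assay does not separate the two groups, despite the larger heavy-atom count of dibutylamino. Nothing available here explains this result.

Still open, from the compounds shown here alone, is whether morpholino, piperidino or a longer chain such as dioctylamino on the sulfonyl sulfur would move the number beyond the scatter. Also open, going by these compounds, is whether dibutylamino would behave the same way when the carbamate oxygen of compound 3 is replaced by a urea nitrogen.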